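The source may report more compounds than this note shows. Statements on the series, on what has been measured and on what is new or still open speak of the compounds shown alone.

In a physicochemical assay for lipophilicity, at pH 7.4 (on this read-out lower numbers stand for lower lipophilicity and higher numbers for higher lipophilicity), compound 1 `Cc1cc(/C=C/C#N)cc(C)c1Oc1cc(Nc2ccc(C#N)cc2)c(N)cc1C(N)=O` gives 3.53. Compound 2 `Cc1cc(CCC#N)cc(C)c1Oc1cc(Nc2ccc(C#N)cc2)c(N)cc1C(F)(F)F` gives no number, only a limit of the assay, > 5. Its place among the values shown is therefore that of a limit.

Compound 3 `Cc1cc(/C=C/C#N)cc(C)c1Oc1cc(Nc2ccc(C#N)cc2)c(N)cc1C(F)(F)F` departs from compound 2 in one place. It has 2-cyanoethenyl in place of 2-cyanoethyl on an aromatic carbon, meta to two methyl groups and para to a large group (2-cyanoethenyl in place of 2-cyanoethyl on an aromatic carbon). Going by the values given here, neither group has a ring or a net charge, and the only measured neighbour of compound 3 in this comparison is known only as a limit. Among the compounds with values here, no measured pair shows this change on its own, so the expectation has to start from compound 2 and its limit of > 5.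

In this assay the expected step is small, a number at least 0.20 log units lower from compound 2 to compound 3 (that floor lies within the scatter), downward if it shows at all and not expected to go beyond the usual scatter. Compound 3 could also turn out to give only a limit. Compound 3 is estimated at 4.8, with an expected range of 4.2 to 5.4.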

Compound 3, partition coefficient: > 5
Compound 3: no number, only a limit; the forecaster's own chance of this, stated with the estimate: 45%; middle value at least 0.20 log units from the limit.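

In this assay compound 3 gives > 5, which is a limit of the assay and not a number. The exchange of 2-cyanoethyl for 2-cyanoethenyl therefore cannot be read in size or direction, as both compounds stand at the same limit: the limit of > 5 in this assay, at which 2 of the 3 values shown sit. Going by these compounds alone, what the result adds is the first readable step in this set, for trifluoromethyl in place of carbamoyl on an aromatic carbon with the 2-cyanoethenyl group held constant: it amounts to a number at least 1.47 log units higher from compound 1 to compound 3 (beyond the scatter), and because compound 3 gives only a limit, this step has a floor but no known upper size.

Left open is whether 2-cyanoethyl and 2-cyanoethenyl differ at all on this read-out, which a pair carrying carbamoyl in place of trifluoromethyl could show, since compound 1 gives a number well clear of the limit. Going by these compounds, it also remains open where a group such as an amine, a carboxylic acid or a methyl group on the same aromatic carbon that carries the trifluoromethyl would fall, and whether a longer chain in place of 2-cyanoethyl would stay at the limit.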